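A few compounds are considered here, and "the series" means these few. Any claim that something is new, unique, unknown or untested is made for them only; others in the source may bear on it.

Working notes on the series. Going by the values given here, compound 1 `O=C(CCCc1ccccc1)Nc1nc2ccccc2c(=O)s1` is the only member with a number in hand: in an assay on CHO cells for displacement of a labelled ligand from adenosine receptor A1 (Homo sapiens), read by scintillation counting, with a stated time of 90 min (a higher number here means a weaker inhibitor, a lower number a stronger inhibitor), compound 1 gives 2500 nM. Compound 2 `O=C(CCc1ccc(Cl)c(Cl)c1)Nc1nc2ccccc2c(=O)s1` belongs to the same set, but in this assay compound 2 gives "not determined" (no result reported). Compound 3 `CN(C(=O)CCCc1ccccc1)c1nc2ccccc2c(=O)s1` belongs to it as well, and in this assay compound 3 gives "not determined" (no result reported). Among the compounds with values here, for both no result was reported, so no step between measured compounds can be drawn.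

Compound 4 `O=C(CCCc1ccccc1)Nc1nc2cc(Cl)ccc2c(=O)s1` is the next member. It differs from compound 1 by chloro in place of hydrogen on an aromatic carbon, a chloro in place of hydrogen on an aromatic carbon of the shared core. Within the data shown here, with no comparable step in the data, the size of the change is open; the expectation is a step of a 1.3-fold lower number from compound 1 to compound 4 (0.10 log units; within the scatter) no larger than the usual scatter, in either direction. The estimate for compound 4 in this assay is 2000 nM, with a range of 600 nM to 7000 nM.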

Compound 4, inhibition constant: 785 nM
Compound 4: middle estimate off by 2.5-fold (0.41 log units), on the high side; measured number inside the range.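

Going by these compounds alone, the step of a 3.2-fold lower number from compound 1 to compound 4 (0.50 log units; beyond the scatter) is the first readable one in this assay and comes from a chloro on an aromatic carbon of the shared core, meta to a fused ring and para to a fused ring. It shows that this carbon takes a chloro and that the change lies beyond the scatter, which compound 2 and compound 3 could not show. Nothing in hand bears on why the number moves.

Going by these compounds, whether a fluoro, a methoxy or an amine on the same carbon moves the number as chloro does remains open. So does the effect of chloro on the other carbons of that ring.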